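The source may report more compounds than this note shows. Statements on the series, on what has been measured and on what is new or still open speak of the compounds shown alone.

Three compounds have so far been measured in an assay on isolated protein for inhibition of Rho-associated protein kinase 2 (Homo sapiens), read by scintillation counting, radiometric assay and 33P incorporation, with a stated time of 40 min, in the presence of a further agent that is not named here; a higher number here means a weaker inhibitor, a lower number a stronger inhibitor:

Compound 1, `COc1cccc(OCC(=O)Nc2cccc(NC(=O)c3ccc(N(C)C)cc3)c2)c1`: 5740 nM
Compound 2, `COc1ccc(OCC(=O)Nc2cccc(NC(=O)c3ccc(N(C)C)cc3)c2)cc1F`: 652 nM
Compound 3, `Cc1ccc(C(=O)Nc2cccc(NC(=O)COc3ccc4c(=O)ccoc4c3)c2)cc1`: 22 nM

Compound 3 gives the lowest number of the three; compound 2 and compound 1 give higher numbers, and the gap to each of them lies beyond the scatter. Within the data shown here, the only step between neighbours that differ in one place is an 8.8-fold lower number from compound 1 to compound 2 (0.94 log units; beyond the scatter), and it concerns the aryloxy end of the shared core.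

Compound 4, `O=C(COc1ccc2c(=O)ccoc2c1)Nc1cccc(NC(=O)c2ccc(C(=O)O)cc2)c1`, differs from compound 3 at the other end: carboxy in place of methyl on an aromatic carbon. Among the measured compounds shown here, no measured pair bears directly on this change, so the direction of the step is open. With compound 3 at 22 nM, the estimate for compound 4 is a modest rise in the number, with a range wide enough to admit no change beyond the scatter. Compound 4 is therefore expected to give about 60 nM in this assay, with a range from 15 nM to 300 nM. The expected step is thus a 2.7-fold higher number from compound 3 to compound 4 (0.44 log units; beyond the scatter).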

Compound 4, half-maximal inhibitory concentration: 2030 nM
Beside the measured number, compound 4's estimate is 34-fold (1.53 log units) below it, outside the stated range (above it).
By their numbers in this assay, from the lowest: compound 3; then compound 2; then compound 4; then compound 1.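

Among these compounds, until this pair, the only step that could be read lay at the aryloxy end of the shared core. This pair opens the other end, and in this assay the change from 4-methylphenyl to 4-carboxyphenyl, on an aromatic carbon para to a large group, gives a 92-fold higher number from compound 3 to compound 4 (1.97 log units; beyond the scatter), so the number is clearly sensitive to what stands at this position. Nothing available here gives a measured reason for the size of this step.

The compounds shown cannot tell whether the rise belongs to the carboxy group itself or to replacing methyl with any group of more heavy atoms; a methyl ester, a primary carboxamide or a hydroxymethyl group at this place would bear on that. They also leave open how a smaller substituent, such as a single fluorine or a hydrogen, would compare with methyl here.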